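Methylamino in place of methoxy on the shared core

The compounds below may be only part of what the source reports. "The series", "measured", "known", "first", "only" and "open" are said of these compounds alone.

Among the compounds with values here, in a functional assay on HCT-116 cells (Homo sapiens) for antiproliferative activity, read by MTT assay, with a stated time of 48 h (on this read-out higher numbers stand for weaker inhibition and lower numbers for stronger inhibition), compound 3 `CCCCCCCC(CCO)n1cnc2c(OC)ncnc21` gives 15300 nM, the only value so far that is a number and not a limit. Compound 1 `CCCCCC(CCO)n1cnc2c(NC)ncnc21` reports only a limit, > 50000 nM. Compound 2 `CCCCCCC(CCO)n1cnc2c(NC)ncnc21` also reports only a limit, > 50000 nM. Compound 4 `CCCCCCCC(CCO)n1cnc2c(NC)ncnc21` differs from compound 3 by one change, methylamino in place of methoxy on an aromatic carbon. Within the data shown here, the one measured step, a step that the two limits leave unreadable from compound 1 to compound 2, gives no size to work from, and no measured pair isolates this exchange. Compounds 1 and 2 also carry methylamino, on a different chain, and their place at the limit of > 50000 nM in this assay, at which 2 of the 3 values shown sit, points to a modest weakening in this assay, with a real chance of another limit. The expected step is a 1.8-fold higher number from compound 3 to compound 4 (0.26 log units; within the scatter). For compound 4 the estimated value is 28000 nM, with an expected range of 9000 nM to 80000 nM.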

Compound 4, half-maximal inhibitory concentration: 12500 nM
The estimate for compound 4 lay 2.2-fold (0.35 log units) above the measured number; measured number inside the range.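

In this assay, the exchange at this position now has a measured size, a 1.2-fold lower number from compound 3 to compound 4 (0.09 log units; within the scatter), so methylamino and methoxy on this aromatic carbon of the shared core cannot be told apart here. With methylamino held constant, the chain makes the readable difference: an at least 4.0-fold lower number from compound 2 to compound 4 (0.60 log units; beyond the scatter), and an at least 4.0-fold lower number from compound 1 to compound 4 (0.60 log units; beyond the scatter). Both of these steps start from a limit and give no exact size: the limit of > 50000 nM in this assay, at which 2 of the 4 values shown sit.

As far as these compounds go, whether a longer chain lowers the number further remains open. So does whether a larger group at this position, such as dimethylamino or ethoxy, stays level with methylamino and methoxy.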